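One Smaller Group on the Sulfur

The compounds below may be only part of what the source reports. "The series", "measured", "known", "first", "only" and "open" are said of these compounds alone.

Values so far in a physicochemical assay for lipophilicity (a lower number here means a more polar compound, a higher number a more lipophilic compound), are as follows:
compound 1 `CCCCCCCN(CCCCCSc1nc(O)c2ccccc2n1)C(=O)Nc1ccc(F)cc1F` gives 6.17 as measured
compound 2 `CCCCCCCN(CCCCCSc1nc(N)c2c[nH]nc2n1)C(=O)Nc1ccc(F)cc1F` gives 5.74 as measured

Of these two, compound 2 stands lowest, with 5.74 on record in this assay and compound 1 above it. The next compound, compound 3 `CCCCCCCN(CCCCCSc1[nH]cnc2nncc1-2)C(=O)Nc1ccc(F)cc1F`, has not yet been measured. Its difference from compound 2 is a group of 9 heavy atoms (5 carbon, 4 nitrogen; one five-membered aromatic ring with 2 hetero atoms, one six-membered aromatic ring with 2 hetero atoms) in place of a group of 10 heavy atoms (5 carbon, 5 nitrogen; one five-membered aromatic ring with 2 hetero atoms, one six-membered aromatic ring with 2 hetero atoms), on a sulfur and the change lies on a sulfur whose other neighbours are saturated chain carbon.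

Among the measured compounds shown here, only one measured step bears on this change: a number 0.43 log units lower from compound 1 to compound 2 (beyond the scatter) is the single case in which the group on the sulfur was exchanged. That step involved a different pair of groups, so it suggests a likely size but no firm direction. Going by the modest size of a number 0.43 log units lower from compound 1 to compound 2 (beyond the scatter) only a small step is expected here, leaning upward and possibly not beyond the scatter. The expected step is a number 0.16 log units higher from compound 2 to compound 3 (within the scatter) and this is an estimate only. The estimate for compound 3 is 5.9 with a range of 5.5 to 6.3 expected once it is measured.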

Compound 3, partition coefficient: 5.6
Estimate against measurement, compound 3: 0.30 log units above; the measured number falls inside the stated range.
By their numbers in this assay, from the lowest: compounds 3 and 2 (each within the scatter of the next); then compound 1.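

On the sulfur whose other neighbours are saturated chain carbon, the group of 9 heavy atoms and the group of 10 heavy atoms, each with one five-membered aromatic ring with 2 hetero atoms and one six-membered aromatic ring with 2 hetero atoms, cannot be told apart in this assay: the exchange gives a number 0.14 log units lower from compound 2 to compound 3 (within the scatter), although the entering group has 1 hydrogen-bond donor and 3 hydrogen-bond acceptors where the leaving group has 2 and 4. The group of 11 heavy atoms, with its six-membered aromatic ring of carbon only, now stands apart from both of the other groups, with a number 0.57 log units lower from compound 1 to compound 3 (beyond the scatter) alongside the earlier a number 0.43 log units lower from compound 1 to compound 2 (beyond the scatter), so two separate exchanges on the sulfur give steps beyond the scatter from compound 1. No measurement at hand accounts for any of these steps.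

The compounds shown leave open whether a group carrying a carboxylic acid or a simple amine on the sulfur would give a step beyond the scatter from compound 3. They also leave open which part of the group of 11 heavy atoms goes with the gap, since its rings and its atoms all differ at once from those of the other two groups.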